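A few compounds are considered here, and "the series" means these few. Any claim that something is new, unique, unknown or untested is made for them only; others in the source may bear on it.

Working notes on the series. In a functional assay on MCF7 cells (Homo sapiens) for antiproliferative activity, read by MTT assay, with a stated time of 48 h (on this read-out higher numbers stand for weaker inhibition and lower numbers for stronger inhibition), compound 1 (`COc1ccc(-c2c(Nc3ccc(F)cc3)c3ccc(OC)cc3oc2=O)cc1`) gives > 100000 nM. That value is a limit and not a number. For the measured compounds named here, compound 2 (`COc1ccc(-c2c(Nc3ccc(C)c(O)c3)c3ccc(OC)cc3oc2=O)cc1`) gives 34400 nM, the only actual number so far in this assay. Going by the values given here, the sole comparison for it is the result for compound 1.

Compound 3 (`COc1ccc(-c2c(Nc3ccc(C)cc3)c3ccc(OC)cc3oc2=O)cc1`) differs from compound 2 by hydrogen in place of hydroxy on an aromatic carbon, ortho to a methyl group: hydrogen in place of hydroxy on an aromatic carbon. The group thus goes from 3-hydroxy-4-methylphenyl to 4-methylphenyl.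

Among the compounds with values here, the only measured step that bears on this is an at least 2.9-fold lower number from compound 1 to compound 2 (0.46 log units; beyond the scatter). Going by these compounds, it introduces the hydroxy and the methyl group together in place of the fluorine-bearing group, so it does not isolate the hydroxy, and its size remains open on one side (the limit of > 100000 nM in this assay, at which 1 of the 2 values shown sits).

Taking that step as a guide, a modest move to a higher number is expected in this assay, of no greater size than the data can support. The expected change is a 1.9-fold higher number from compound 2 to compound 3 (0.28 log units; within the scatter). A result reported only as a limit remains a real possibility. For compound 3 the estimate is 65000 nM, with an expected range of 28000 nM to 100000 nM.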

Compound 3, half-maximal inhibitory concentration: 66900 nM
Beside the measured number, compound 3's estimate is 1.0-fold (0.01 log units) below it, within the range that was stated.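

Taken alone, the hydroxy ortho to a methyl group gives, in this assay, a 1.9-fold higher number from compound 2 to compound 3 (0.29 log units; within the scatter), so this read-out does not separate hydroxy from hydrogen at this place on the ring, and the combined step from the fluorine-bearing group no longer points to the hydroxy as the part that counts. The other half of that combined change, methyl in place of fluoro on an aromatic carbon, reads as an at least 1.4-fold lower number from compound 1 to compound 3 (0.17 log units; that floor lies within the scatter), so it too is not shown to clear the scatter, though only its floor is known. The value for compound 1 is a limit and not a number, which leaves this step open on one side: the limit of > 100000 nM in this assay, at which 1 of the 3 values shown sits.

Going by these compounds, whether an amine or a carboxylic acid at the hydroxy's place would separate from compound 2 and compound 3 in this assay remains open. Also open, on these data alone, is whether a longer chain in place of the methyl group, or a chlorine in place of the fluorine of compound 1, would give a clear step on this read-out.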